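Swapping a Dichlorophenyl Ring for a Hydroxyphenyl Ring

A few compounds are considered here, and "the series" means these few. Any claim that something is new, unique, unknown or untested is made for them only; others in the source may bear on it.

Of the compounds shown here, three sharing a triaryl alkene scaffold have been tested in a functional assay on HeLa cells (Homo sapiens) for inhibition, read by trypan blue exclusion, with a stated time of 72 h; a lower number here means a stronger inhibitor of growth, a higher number a weaker inhibitor of growth. Compound 1 `CC/C(=C(\c1ccccc1)c1ccc(NC(=O)C(C)C)cc1)c1ccc(Cl)cc1Cl` gives 3300 nM in this assay. Compound 2 `CC/C(=C(\c1ccc(NC(=O)C(C)C)cc1)c1ccc(OC)cc1)c1ccc(O)cc1` gives 3700 nM in this assay, and compound 3 `CC/C(=C(\c1ccc(NC(=O)C(C)C)cc1)c1ccc(OC)cc1)c1ccc(Cl)cc1Cl` gives 5500 nM in this assay. The three numbers all lie close together.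

Compound 2 and compound 3 differ in one place only: 4-hydroxyphenyl in place of 2,4-dichlorophenyl on a double-bonded chain carbon bound to a double-bonded chain carbon and a saturated chain carbon. This change brought a 1.5-fold lower number from compound 3 to compound 2 (0.17 log units; within the scatter) in this assay.

Compound 4 `CC/C(=C(\c1ccccc1)c1ccc(NC(=O)C(C)C)cc1)c1ccc(O)cc1` has not yet been measured. It is related to compound 1 by the same change: 4-hydroxyphenyl in place of 2,4-dichlorophenyl on a double-bonded chain carbon bound to a double-bonded chain carbon and a saturated chain carbon. The difference between the core of compound 1 and the core of compound 3 is not broken down here.

Because the earlier step of a 1.5-fold lower number from compound 3 to compound 2 (0.17 log units; within the scatter) stayed within the scatter, the step from compound 1 to compound 4 is expected to be similarly small, about a 1.3-fold lower number from compound 1 to compound 4 (0.12 log units; within the scatter) in this assay. Compound 4 is therefore estimated to give around 2500 nM in this assay, most likely between 1200 nM and 5500 nM.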

Compound 4, concentration for 50% growth inhibition: 3800 nM
Compound 4: the middle estimate sits 1.5-fold (0.18 log units) below what was measured; low and high end bracket the measured number.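

Putting 4-hydroxyphenyl in place of 2,4-dichlorophenyl on the core of compound 1 brought a 1.2-fold higher number from compound 1 to compound 4 (0.06 log units; within the scatter) in this assay. Set beside the earlier step on the other core, the change gives a matching picture: the same change on two cores in this assay, a 1.5-fold lower number (0.17 log units; within the scatter) from compound 3 to compound 2 and a 1.2-fold higher number (0.06 log units; within the scatter) from compound 1 to compound 4, 1.7-fold (0.23 log units) apart, within the scatter of two such steps So on both cores shown, the swap left the number within the scatter, but this does not show that the two groups are interchangeable on other cores, and with no step beyond the scatter, it cannot show whether a large effect would carry from one core to another.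

The compounds shown leave open whether a different group at this place, such as a ring carrying an amine or a carboxylic acid, or a longer chain, would move the number beyond the scatter. They also leave open how each separate difference between the core of compound 1 and the core of compound 3 contributes on its own.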